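The compounds below may be only part of what the source reports. "The series", "measured", "known", "first", "only" and "open" are said of these compounds alone.

Measured so far:
- compound 1 `Nc1cc(N)c2nc(-c3ccccc3)c(NCc3ccc(F)cc3)nc2c1`: 6610 nM
- compound 2 `Nc1cc(N)c2nc(-c3ccccc3)c(Sc3ccc(Cl)c(Cl)c3)nc2c1`: 17000 nM

Both compounds share a core and differ only in the group hanging from it. In a functional assay on SNB-19 cells (Homo sapiens) for inhibition, read by sulforhodamine B assay, with a stated time of 48 h (a higher number here means a weaker inhibitor of growth, a lower number a stronger inhibitor of growth), compound 1 gives 6610 nM, and compound 2 gives 17000 nM, the highest of the two numbers; the step of a 2.6-fold higher number from compound 1 to compound 2 (0.41 log units; beyond the scatter) marks compound 2 as the weaker of the pair.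

Compound 3 `Nc1cc(N)c2nc(-c3ccccc3)c(Sc3ccc(F)cc3)nc2c1` is not yet measured. It differs from compound 2 by 4-fluorophenyl in place of 3,4-dichlorophenyl on a sulfur. Going by the values given here, no measured step changes only the aryl group on the sulfur: the single step from compound 1 to compound 2 swaps both the linker and the aryl at once, so it speaks only indirectly to this change. The change to compound 3 keeps the sulfur linker of compound 2 and borrows the 4-fluorophenyl pattern seen in compound 1, which gave 6610 nM, so a shift toward compound 1 is possible but not assured. The expected step is a 1.4-fold lower number from compound 2 to compound 3 (0.15 log units; within the scatter), within the scatter. Compound 3 is therefore estimated at 12000 nM in this assay, with a range from 4000 nM to 35000 nM.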

Compound 3, concentration for 50% growth inhibition: 20000 nM
Beside the measured number, compound 3's estimate is 1.7-fold (0.22 log units) below it, within the range that was stated.
By their numbers in this assay, from the lowest: compound 1; then compounds 2 and 3 (each within the scatter of the next).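

In this assay, going by these compounds alone, the change to 4-fluorophenyl on the sulfur gives a 1.2-fold higher number from compound 2 to compound 3 (0.07 log units; within the scatter), the first step here that alters only the aryl group, and it shows no readable effect of that change. The wider swap of (4-fluorobenzyl)amino for (4-fluorophenyl)sulfanyl on the aromatic carbon gives a 3.0-fold higher number from compound 1 to compound 3 (0.48 log units; beyond the scatter), a modest step beyond the scatter. With the fluorine-bearing ring present on both sides of that step, the difference goes with the rest of the group: the sulfur in place of the amino link, and phenyl in place of benzyl. Nothing in the data explains either step.

The compounds shown leave open whether the sulfur or the benzyl carbon matters more, since (4-fluorobenzyl)sulfanyl or (4-fluorophenyl)amino at this position would separate the two. They also leave open whether the aryl group on the sulfur can influence growth inhibition at all, which a group of another kind there, such as a carboxylic acid on the ring or a longer alkyl chain in place of the ring, could test.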